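Swapping the aryl group on the triazole nitrogen

The source may hold more compounds than are shown below. What is called first, only, known or untested is meant among the compounds shown, and "the series" means these compounds.

Of the compounds shown here, two have been measured in an ADME assay on HUVEC cells (Homo sapiens) for antiproliferative activity, read by MTT assay, with a stated time of 48 h; a higher number here means a weaker inhibitor, a lower number a stronger inhibitor. Compound 1, `Cc1ccccc1-n1nncc1CN1C(=O)C2(C(C#N)=C(N)Oc3c2c2nc4ccccc4nc2c2ccccc32)c2ccccc21`, gives > 50000 nM, which is a limit of the assay and not a number. Compound 2, `N#CC1=C(N)Oc2c(N)cc3nc4ccccc4nc3c2C12C(=O)N(Cc1cnnn1-c1cccc(C(F)(F)F)c1)c1ccccc12`, likewise gives > 50000 nM, again only a limit. Both values therefore sit at the limit of > 50000 nM in this assay, at which 2 of the 2 values shown sit, so compound 2 stands where compound 1 stands, and no order between the two can be read from the numbers.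

Compound 3, `Cc1cc(C)c(-n2nncc2CN2C(=O)C3(C(C#N)=C(N)Oc4c(N)cc5nc6ccccc6nc5c43)c3ccccc32)c(C)c1`, has not yet been measured in this assay. It differs from compound 2 in one place: 2,4,6-trimethylphenyl in place of 3-(trifluoromethyl)phenyl on an aromatic nitrogen. Among the compounds with values here, with both measured compounds at the limit, there is no measured step to lean on. The expected step that the limit leaves unreadable from compound 2 to compound 3 is none beyond the scatter. Compound 3 is estimated to give 60000 nM, with a range from 20000 nM to 200000 nM, most likely reported again as a limit.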

Compound 3, half-maximal inhibitory concentration: > 50000 nM
Compound 3: a limit, no number (the forecaster's own chance of this, stated with the estimate: 80%); the middle value lies beyond the limit too.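

Compound 3, like compound 2, gives only a limit of the assay and not a number, so no step between compound 2 and compound 3 can be read: the limit of > 50000 nM in this assay, at which 3 of the 3 values shown sit.

The compounds shown leave open whether the group on the aromatic nitrogen changes the result in this assay at all.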